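Hydroxymethyl in Place of Methyl on the Pendant Phenyl

A few compounds are considered here, and "the series" means these few. Any claim that something is new, unique, unknown or untested is made for them only; others in the source may bear on it.

Compound 1 `Cc1cccc(C2(CNC(=O)Nc3c(C(C)C)cccc3C(C)C)CCCC2)c1` is the strongest of the three measured compounds: in an assay on microsomes for inhibition of acyl-CoA:cholesterol acyltransferase (Oryctolagus cuniculus) (a lower number here means a stronger inhibitor, a higher number a weaker inhibitor), compound 1 gives 15 nM, the lowest number in this set. Compound 2 `CC(C)c1cccc(C(C)C)c1NC(=O)NCC1(c2cccc(N)c2)CCCC1`, with amino in place of methyl on an aromatic carbon, gives 21 nM, a change of a 1.4-fold higher number from compound 1 to compound 2 (0.15 log units; within the scatter). Compound 3 `CC(C)c1cccc(C(C)C)c1NC(=O)NCC1(c2ccc(C(=O)O)cc2)CCCC1`, carrying 4-carboxyphenyl in place of 3-methylphenyl, gives 3100 nM, a loss of a 210-fold higher number from compound 1 to compound 3 (2.32 log units; beyond the scatter).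

Compound 4 `CC(C)c1cccc(C(C)C)c1NC(=O)NCC1(c2ccc(CO)cc2)CCCC1` has not yet been measured. It differs from compound 1 as follows: 4-(hydroxymethyl)phenyl in place of 3-methylphenyl on a saturated ring carbon. Within the data shown here, two measured steps bear on this change. The step of a 1.4-fold higher number from compound 1 to compound 2 (0.15 log units; within the scatter) shows that adding a hydrogen-bond donor to the pendant phenyl need not cost potency, while the step of a 210-fold higher number from compound 1 to compound 3 (2.32 log units; beyond the scatter) shows that a 4-carboxyphenyl does cost a great deal. A 4-(hydroxymethyl)phenyl lies between these cases, so a moderate loss is expected. Compound 4 is therefore estimated at 100 nM, within 25 nM to 500 nM, meaning an expected step of a 6.7-fold higher number from compound 1 to compound 4 (0.82 log units; beyond the scatter).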

Compound 4, half-maximal inhibitory concentration: 26 nM
For compound 4 the middle estimate is 3.8-fold (0.59 log units) above the measured one; the range from low to high includes it.
By their numbers in this assay, from the lowest: compounds 1, 2 and 4 (each within the scatter of the next); then compound 3.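

In this assay, 4-(hydroxymethyl)phenyl on the saturated ring carbon is tolerated (a 1.7-fold higher number from compound 1 to compound 4 (0.24 log units; within the scatter)), and it also stands level with the 3-aminophenyl of compound 2 (a 1.2-fold higher number from compound 2 to compound 4 (0.09 log units; within the scatter)). Replacing carboxy with hydroxymethyl on the same aromatic carbon gives a large recovery (a 120-fold lower number from compound 3 to compound 4 (2.08 log units; beyond the scatter)), so the loss seen with compound 3 goes with the carboxy group and not with having a group in that place on the phenyl. Nothing measured here explains this difference between hydroxymethyl and carboxy.

Compounds 1 and 4 differ in both the group and its place on the phenyl, so a 4-methylphenyl would be needed to separate those two changes. A methyl ester or an aminomethyl group in the same place would show how closely the large loss is tied to the carboxylic acid itself.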